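The source may report more compounds than this note shows. Statements on the series, on what has been measured and on what is new or still open speak of the compounds shown alone.

Of the compounds shown here, three have been read so far in a functional assay on PC-3 cells (Homo sapiens) for antiproliferative activity, with a stated time of 48 h; on this read-out lower numbers stand for stronger inhibition and higher numbers for weaker inhibition. Compound 1 `COc1ccc(Nc2ccc(-c3ccccc3)nn2)cc1` gives > 25000 nM, a limit and not a number. Compound 2 `CCN(CC)c1ccc(-c2cccc(Cl)c2)nn1` gives > 25000 nM, which is also a limit. Compound 3 `CCN(CC)c1ccc(-c2ccc(C(C)=O)cc2)nn1` gives > 25000 nM, again a limit. Compound 2 therefore has no numerical position in the series and stands with the other two at the limit of > 25000 nM in this assay, at which 3 of the 3 values shown sit.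

Compound 4 `CCOC(=O)c1cccc(-c2ccc(N(CC)CC)nn2)c1` is not yet measured. Its change from compound 2 is ethoxycarbonyl in place of chloro on an aromatic carbon, meta to a large group: ethoxycarbonyl in place of chloro on an aromatic carbon. Going by the values given here, no two measured compounds differ in one place, so no measured step sets the size of this change.

The expectation leans on compound 3, which also carries a carbonyl in its substituent and gives > 25000 nM, a limit. The estimated step of a number no higher from compound 2 to compound 4 (the limit leaves the size open) is expected to stay within the scatter, with no direction favoured, and a further report of only a limit is the likeliest outcome. For compound 4 the expected value is 25000 nM, with an estimated range of 10000 nM to 50000 nM.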

Compound 4, half-maximal inhibitory concentration: > 25000 nM
Compound 4 ended at the assay's limit; the forecaster's own chance of this, stated with the estimate: 75%; the middle value sits exactly at the limit.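

In this assay compound 4 gives > 25000 nM, a limit and not a number. Compound 2 also stands at a limit, and the step between compound 2 and compound 4 cannot be read. The compounds shown leave open which change to the shared core, if any, would give a measurable value, as all remain at one point: the limit of > 25000 nM in this assay, at which 4 of the 4 values shown sit.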